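The compounds below may be only part of what the source reports. "The series", "measured", "known", "first", "only" and "open" are said of these compounds alone.

Compounds measured so far in an ADME assay on MT4 cells (Homo sapiens) for cytotoxicity, read by MTT assay, with a stated time of 5 days; on this read-out lower numbers stand for higher toxicity in this test and higher numbers for lower toxicity in this test:
compound 1, `Cc1cc(C)c(Oc2cc(Nc3ccc(C#N)cc3)ncc2C(=O)NCc2cn(Cc3cccc(F)c3)nn2)c(C)c1`: >= 204000 nM
compound 2, `Cc1cc(C)c(Oc2cc(Nc3ccc(C#N)cc3)ncc2C(=O)NCc2cn(CC(=O)N3CCOCC3)nn2)c(C)c1`: 181000 nM

Compound 1 reaches only a limit of the assay in this assay, not a number, so where it stands is known only as that limit (the limit of >= 204000 nM in this assay, at which 1 of the 2 values shown sits). Compound 2 gives 181000 nM in this assay. For the measured compounds named here, the one measured step, an at least 1.1-fold lower number from compound 1 to compound 2 (0.05 log units; that floor lies within the scatter), is too small to separate from the scatter of the method, so both compounds appear equally low in toxicity here.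

Compound 3, `Cc1cc(C)c(Oc2cc(Nc3ccc(C#N)cc3)ncc2C(=O)NCc2cn(Cc3ccccc3C)nn2)c(C)c1`, is yet to be measured. It differs from compound 1 in one place: 2-methylphenyl in place of 3-fluorophenyl on a saturated chain carbon bound to an aromatic nitrogen. Going by the values given here, no measured step swaps exactly this group. Among the compounds with values here, the only step that touches the same place, an at least 1.1-fold lower number from compound 1 to compound 2 (0.05 log units; that floor lies within the scatter), exchanges a larger, more polar group and still stays within the scatter, and compound 1 itself sits at the limit, so the expected outcome for compound 3 is no step beyond the scatter. The expected step from compound 1 is a number no higher from compound 1 to compound 3 (the limit leaves the size open). Compound 3 is therefore estimated at 204000 nM, with a range from 100000 nM to 420000 nM, most likely again reported only as a limit.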

Compound 3, half-maximal cytotoxic concentration: >= 164000 nM
Compound 3: only a limit was reported (the forecaster's own chance of this, stated with the estimate: 65%); the middle value lies beyond the limit too.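

In this assay compound 3 gives only a limit, not a number, so its steps from compound 1 and from compound 2 cannot be read: the limit of >= 164000 nM in this assay, at which 1 of the 3 values shown sits. Compound 1 also gives only a limit: the limit of >= 204000 nM in this assay, at which 1 of the 3 values shown sits. Left open is where compound 1 and compound 3 truly stand, and so whether 2-methylphenyl in place of 3-fluorophenyl changes the number at all.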